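The source may hold more compounds than are shown below. What is called first, only, known or untested is meant among the compounds shown, and "the series" means these compounds.

Compound 3, `CC1=C(C(=O)Nc2ccc(Br)cc2)C(c2ccc(Cl)cc2Cl)N=C(SCc2ccccc2)N1`, gives 13.4% in a functional assay on the whole organism (artery, strain albino) with Rattus norvegicus as the target, with a stated time of 180 min, at a dose of 10 mg/kg by the oral route (on this read-out higher numbers stand for more inhibition at the one dose given (going by the name of the read-out) and lower numbers for less inhibition), and on this read-out it stands level with compound 1, `COc1ccc(C2N=C(SCc3cccc(Cl)c3)NC(C)=C2C(=O)Nc2ccc(F)cc2)cc1OC`, which gives 13.4%; compound 2, `CC1=C(C(=O)Nc2ccc(F)cc2)C(c2ccc([N+](=O)[O-])cc2)N=C(SCc2cccc(Cl)c2)N1`, gives 11.9%. Among the measured compounds shown here, the one measured step among them, a number 1.5 percentage points lower from compound 1 to compound 2 (within the scatter), changes a different part of the shared core and stays within the scatter. Compound 4, `CC1=C(C(=O)Nc2ccc(Br)cc2)C(c2ccc(Cl)cc2Cl)N=C(SCc2cccc(Cl)c2)N1`, differs from compound 3 by chloro in place of hydrogen on an aromatic carbon. For the measured compounds named here, no measured step touches the benzylsulfanyl side, so nothing measured bears directly on this change; compound 1 and compound 2 already carry (3-chlorobenzyl)sulfanyl and sit in the same range as compound 3. Compound 4 is therefore expected to show a number 0.4 percentage points lower from compound 3 to compound 4 (within the scatter). The estimate for compound 4 is 13%, within 5% to 21%.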

Compound 4, a percentage reported as inhibition, in the whole organism at one dose (the size of the read-out at that dose, not a potency): 11.9%
The estimate for compound 4 lay 1.1 percentage points above the measured number, and the stated range covers the measured number.
By their numbers in this assay, from the lowest: compounds 2, 4, 1 and 3 (each within the scatter of the next).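

Going from benzylsulfanyl to (3-chlorobenzyl)sulfanyl gives a number 1.5 percentage points lower from compound 3 to compound 4 (within the scatter) in this assay. Among the compounds shown here, this is the first measured step on this side of the shared core, and at this one dose, chloro on this aromatic carbon moves the read-out by no more than the scatter. Nothing available offers a cause for this result.

From the compounds shown here alone, whether an amine or a carboxylic acid at this place on the ring, or a longer chain in place of the benzyl, would move the read-out beyond the scatter stays open. So does whether chloro here would behave the same at another dose.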